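The source may hold more compounds than are shown below. What is called first, only, known or untested is meant among the compounds shown, and "the series" means these compounds.

Working notes on the series. Compound 1 `CCCCCNc1nc(SCC)nc2ncccc12`, compound 2 `CCCCCNc1nc(SC(C)C)nc2ncccc12` and compound 3 `CCCCNc1nc(SCCCC)nc2ncccc12` have been measured; compound 4 `CCCCCNc1nc(SCCCC)nc2ncccc12` has not. In a functional assay on T-24 cells (Homo sapiens) for cytotoxicity, read by neutral red uptake, with a stated time of 72 h (on this read-out higher numbers stand for weaker inhibition and lower numbers for stronger inhibition), compound 1 gives 4300 nM, compound 2 gives 7900 nM and compound 3 gives 10600 nM. Compound 3 stands highest of the three, though its gap to compound 2 is within the scatter; only its gap to compound 1 is beyond it. The difference between the core of compound 1 and the core of compound 3 is not broken down here.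

One change recurs. From compound 1 to compound 2 it is methyl in place of hydrogen on a saturated chain carbon bound to a saturated chain carbon and a sulfur, and it made a step of a 1.8-fold higher number from compound 1 to compound 2 (0.26 log units; within the scatter) in this assay. From compound 3 to compound 4 the change is methyl in place of hydrogen on a saturated chain carbon, four bonds along the chain from a nitrogen on an aromatic ring, the same kind of change but at another place: on a saturated chain carbon bound to a saturated chain carbon and a sulfur in the first case, on a saturated chain carbon four bonds along the chain from a nitrogen on an aromatic ring in the second. A comparably small step is expected in this assay from compound 3 to compound 4, a 1.1-fold higher number from compound 3 to compound 4 (0.05 log units; within the scatter), resting on the step of a 1.8-fold higher number from compound 1 to compound 2 (0.26 log units; within the scatter). Compound 4 is therefore estimated at 12000 nM, expected between 5000 nM and 30000 nM.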

Compound 4, half-maximal inhibitory concentration: 8900 nM
Estimate against measurement, compound 4: 1.3-fold (0.13 log units) above; low and high end bracket the measured number.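

Carried to the core of compound 3, methyl in place of hydrogen gives a 1.2-fold lower number from compound 3 to compound 4 (0.08 log units; within the scatter) in this assay and so no step that can be told from the scatter. This does not show that the change is without effect on either core, nor that it would act alike at one and the same place; the two steps sit at different places, one on the chain on the sulfur and one on the chain on the nitrogen. Set side by side, the two steps cannot be told apart: the same change on two cores in this assay, a 1.8-fold higher number (0.26 log units; within the scatter) from compound 1 to compound 2 and a 1.2-fold lower number (0.08 log units; within the scatter) from compound 3 to compound 4, 2.2-fold (0.34 log units) apart, within the scatter of two such steps

On the chain on the sulfur, a 1.1-fold higher number from compound 2 to compound 4 (0.05 log units; within the scatter) for butyl in place of isopropyl and a 2.1-fold higher number from compound 1 to compound 4 (0.32 log units; beyond the scatter) for ethyl in place of hydrogen are single pairs, and they leave open what a chain longer than butyl would do there, or a chain ending in an amine or a carboxylic acid. Whether the methyl step stays as small on a third core is open as well.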